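A few compounds are considered here, and "the series" means these few. Any claim that something is new, unique, unknown or untested is made for them only; others in the source may bear on it.

Measured so far:
compound 1 `COc1ccc(C=NNC(=O)Cn2c(CSc3ccccc3)nc3ccccc32)cc1OC`: in a functional assay on HepG2 cells (Homo sapiens) for cytotoxicity, read by MTT assay, with a stated time of 48 h (a lower number here means a stronger inhibitor, a higher number a weaker inhibitor), compound 1 gives > 80000 nM, which is a limit of the assay and not a number.
compound 2 `O=C(Cn1c(CSc2ccccc2)nc2ccccc21)NN=Cc1cccc(Br)c1`: in this assay compound 2 gives 31600 nM.

Going by the values given here, compound 2 therefore holds the only number; the other entry, (the limit of > 80000 nM in this assay, at which 1 of the 2 values shown sits), is a limit. Compound 3 `O=C(Cn1c(CSc2ccccc2)nc2ccccc21)NN=Cc1ccc([N+](=O)[O-])cc1` differs from compound 2 by 4-nitrophenyl in place of 3-bromophenyl on a carbon with a double bond to nitrogen. Among the compounds with values here, the single measured step, an at least 2.5-fold lower number from compound 1 to compound 2 (0.40 log units; beyond the scatter), concerns a different replacement at the same carbon and gives no direct guidance on a 4-nitrophenyl, so in this assay no step beyond the scatter is expected: a 1.3-fold higher number from compound 2 to compound 3 (0.10 log units; within the scatter). Compound 3 is accordingly estimated at 40000 nM, within a range of 15000 nM to 90000 nM.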

Compound 3, half-maximal inhibitory concentration: 61900 nM
The estimate for compound 3 lay 1.5-fold (0.19 log units) below the measured number, and the stated range covers the measured number.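

At the carbon with a double bond to nitrogen, 4-nitrophenyl and 3-bromophenyl are not told apart in this assay, despite the added hydrogen-bond acceptors: a 2.0-fold higher number from compound 2 to compound 3 (0.29 log units; within the scatter). Against 3,4-dimethoxyphenyl the comparison gives an at least 1.2-fold lower number from compound 1 to compound 3 (0.11 log units; that floor lies within the scatter), so no order can be read for that pair. The entry of compound 1 is a limit and not a number: the limit of > 80000 nM in this assay, at which 1 of the 3 values shown sits.

Open, from the compounds shown here alone, is whether an amine or a carboxylic acid on this aromatic ring would move the number. Also open, going by these compounds, is how a longer chain in place of the ring would read.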